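The source may report more compounds than this note shows. Statements on the series, on what has been measured and on what is new or still open speak of the compounds shown alone.

Measured so far in a functional assay on BGC-823 cells (Homo sapiens) for antiproliferative activity, read by MTT assay, tested at 5 uM; a higher number here means a stronger effect of the compound at the concentration tested, a lower number a weaker effect:
compound 1, `COc1cc(C(=O)N/N=C/c2ccc(F)c(F)c2)cc(OC)c1OC`: 51.9%
compound 2, `COc1cc(C2=NN(C(C)=O)C(c3cccc(OC)c3OC)O2)cc(OC)c1OC`: 17.5%
compound 3, `COc1ccc(C2OC(c3cc(OC)c(OC)c(OC)c3)=NN2C(C)=O)c(OC)c1`: -3.1%

Compound 3 stands lowest of the three numbers; compound 2 is the nearest to it and compound 1 the furthest, both higher and both beyond the scatter. Compound 4, `COc1cc(C2=NN(C(C)=O)C(c3ccccc3C(F)(F)F)O2)cc(OC)c1OC`, differs from compound 3 in one place: 2-(trifluoromethyl)phenyl in place of 2,4-dimethoxyphenyl on a saturated ring carbon. Going by the values given here, one measured step bears on it, the exchange of the aryl group on the same saturated ring carbon, a number 20.6 percentage points lower from compound 2 to compound 3 (beyond the scatter). That single step shows that an aryl exchange at this carbon can move this assay beyond the scatter, but one step in one direction gives no firm direction for a third aryl group, and compound 1, with a different core, does not speak to the change. Compound 4 is therefore expected to lie near compound 3 or somewhat above it, with a wide range. The expected step for compound 4 is a number 15.1 percentage points higher from compound 3 to compound 4 (beyond the scatter). The estimate for compound 4 is 12%, between -8% and 38%.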

Compound 4, a percentage reported as inhibition, at one concentration (the size of the read-out at that concentration, not a potency): 34.8%
Estimate against measurement, compound 4: 22.8 percentage points below, within the range that was stated.
By their numbers in this assay, from the lowest: compound 3; then compound 2; then compound 4; then compound 1.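

In this assay, the aryl group on the saturated ring carbon can move the read-out upward as well as downward: a number 37.9 percentage points higher from compound 3 to compound 4 (beyond the scatter), and a number 17.3 percentage points higher from compound 2 to compound 4 (beyond the scatter). Among the three compounds sharing this core, the two dimethoxyphenyl groups therefore both give lower numbers than 2-(trifluoromethyl)phenyl, so methoxy groups on this aryl ring are not required for the effect seen at this concentration. No available evidence accounts for the size or direction of these steps.

The compounds shown do not separate the contribution of the trifluoromethyl group from that of its place on the phenyl ring. Also open, as far as these compounds go, is how this assay would respond to an amine or a carboxylic acid on this aryl ring, or to a longer chain in place of the acetyl group.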